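Propyl to 1-hydroxyethyl on the shared core

The compounds below may be only part of what the source reports. "The series", "measured", "known", "first", "only" and "open" are said of these compounds alone.

Of the compounds shown here, two with a shared core have been measured in an assay on isolated protein for binding affinity to adenosine receptor A1 (Bos taurus); a lower number here means a stronger inhibitor, a higher number a weaker inhibitor. Compound 1 `CCCNc1nc(-c2ccccc2)nc2c1nnn2Cc1ccccc1F` gives 3200000 nM in this assay, and compound 2 `CCCCNc1nc(-c2ccccc2)nc2c1nnn2Cc1ccccc1F` gives 4300000 nM. Within the data shown here, the single step between them is a 1.3-fold higher number from compound 1 to compound 2 (0.13 log units; within the scatter), so compound 2 stands alongside compound 1 as one of two numbers that the scatter does not separate, and both sit at the weak end of what this assay reports.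

Compound 3 `CC(O)CNc1nc(-c2ccccc2)nc2c1nnn2Cc1ccccc1F` differs from compound 2 by 1-hydroxyethyl in place of propyl on a saturated chain carbon bound to a nitrogen on an aromatic ring. Among the measured compounds shown here, the only measured step, a 1.3-fold higher number from compound 1 to compound 2 (0.13 log units; within the scatter), concerns lengthening the chain further out and says nothing about bringing in a hydroxyl group on the chain carbon bound to the ring nitrogen. For the measured compounds named here, with no step that bears on this change, there is no ground in the data for expecting a shift in this assay beyond the scatter in either direction, and the expected step is a 1.1-fold lower number from compound 2 to compound 3 (0.03 log units; within the scatter). Compound 3 is therefore estimated to give 4000000 nM in this assay, with a range from 1000000 nM to 16000000 nM.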

Compound 3, inhibition constant: 4800000 nM
Compound 3: middle estimate off by 1.2-fold (0.08 log units), on the low side; low and high end bracket the measured number.
By their numbers in this assay, from the lowest: compounds 1, 2 and 3 (each within the scatter of the next).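

In this assay, 1-hydroxyethyl in place of propyl on a saturated chain carbon bound to a nitrogen on an aromatic ring gives a 1.1-fold higher number from compound 2 to compound 3 (0.05 log units; within the scatter), so at this position a chain carrying a hydrogen-bond donor and acceptor is not told apart from the all-carbon chain of compound 2. Read from compound 1, hydroxy in place of hydrogen on a saturated chain carbon bound to two saturated chain carbons gives a 1.5-fold higher number from compound 1 to compound 3 (0.18 log units; within the scatter), which means that the change is not told apart from the shorter unsubstituted chain either, and all three compounds lie within the scatter of one another in this assay. The data at hand offer no explanation for these numbers.

What remains open is whether any group on this chain can move the number in this assay beyond the scatter, since the compounds shown all sit together at the weak end of what is reported. On these data alone, an amine or a carboxylic acid on this chain, or a longer chain such as hexyl, is not among them, so the reach of this flat result beyond propyl, butyl and 2-hydroxypropyl is unknown.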